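Methylation of the phenol in a cytotoxic pyridine series

The compounds below may be only part of what the source reports. "The series", "measured", "known", "first", "only" and "open" are said of these compounds alone.

Measured compounds:
compound 1, `N#CC1=C(N)N(c2ccc(S(N)(=O)=O)cc2)C2=C(CCCC2)C1c1ccc(O)cc1`: 42%
compound 2, `COc1ccc(C2C(C#N)=C(N)N(c3ccc(S(N)(=O)=O)cc3)C3=C2CCCC3)cc1`: 90%
compound 3, `N#CC1=C(N)N(c2ccc(S(N)(=O)=O)cc2)C2=C(CCCC2)C1c1c(O)ccc2ccccc12`: 5%

In a functional assay on Ehrlich cells (Mus musculus) for cytotoxicity, read by trypan blue exclusion, with a stated time of 2 h, tested at 25 ug/mL (on this read-out lower numbers stand for a weaker effect and higher numbers for a stronger effect at the one concentration tested), compound 1 gives 42%, compound 2 gives 90%, and compound 3 gives 5%, the lowest of the three numbers. The change from compound 1 to compound 2 is methyl in place of hydrogen on an oxygen on an aromatic ring, and it made a step of a number 48 percentage points higher from compound 1 to compound 2 (beyond the scatter). The cores of compound 1 and compound 3 differ by 2-hydroxynaphthalen-1-yl in place of 4-hydroxyphenyl on a saturated ring carbon, a step of a number 37 percentage points lower from compound 1 to compound 3 (beyond the scatter); from compound 2 to compound 3 the step is a number 85 percentage points lower from compound 2 to compound 3 (beyond the scatter).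

Compound 4, `COc1ccc2ccccc2c1C1C(C#N)=C(N)N(c2ccc(S(N)(=O)=O)cc2)C2=C1CCCC2`, is not yet measured in this assay. It differs from compound 3 by methyl in place of hydrogen on an oxygen on an aromatic ring, the same change as from compound 1 to compound 2, at a place described in the same words. Going by the values given here, the expectation for compound 4 therefore rests on the one earlier step, a number 48 percentage points higher from compound 1 to compound 2 (beyond the scatter), seen on a different core; whether it carries over is not known from these three compounds. A step of a number 30 percentage points higher from compound 3 to compound 4 (beyond the scatter) is expected, smaller than the earlier one to allow for the change of core. Compound 4 is estimated at 35%, with a range from 8% to 70%.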

Compound 4, a percentage reported as activity, at one concentration (the size of the read-out at that concentration, not a potency): 10%
Beside the measured number, compound 4's estimate is 25 percentage points above it, and the stated range covers the measured number.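

In this assay, methyl in place of hydrogen on an oxygen on an aromatic ring gives a number 5 percentage points higher from compound 3 to compound 4 (within the scatter), so on this core the change has no effect that can be told from the scatter. Set beside the earlier step, the same change does not carry a fixed size from one core to the other, and the outcome here depends on which core bears it: the same change on two cores in this assay, a number 48 percentage points higher (beyond the scatter) from compound 1 to compound 2 and a number 5 percentage points higher (within the scatter) from compound 3 to compound 4, 43 percentage points apart, beyond the scatter of two such steps This shows that the step on the core of compound 1 cannot be used as a guide for the core of compound 3; it does not show why the two differ, and two pairs give no rule for any further core in the series.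

As far as these compounds go, it remains open whether hydroxy to methoxy is without effect only on the core of compound 3 or also on other aryl groups at that saturated ring carbon. Also open, from the compounds shown here alone, is how either core responds to an ethyl group or a longer chain on that oxygen, or to an amine in place of the hydroxy group.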